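From Hydrogen to Methoxy on Compound 2

The source may report more compounds than this note shows. Statements on the series, on what has been measured and on what is new or still open speak of the compounds shown alone.

In an ADME assay on HepG2 cells (Homo sapiens) for cytotoxicity, read by MTT assay, with a stated time of 48 h (on this read-out lower numbers stand for higher toxicity in this test and higher numbers for lower toxicity in this test), three compounds have been measured so far. Compound 2 `C#CCN(c1nc(-c2ccccc2)no1)C1CCCCC1` gives 109 ug/mL, the highest of the three numbers. Compound 1 `C#CCN(c1nc(-c2cccc([N+](=O)[O-])c2)no1)C1CCCCC1` gives 45.5 ug/mL, and compound 3 `CC(=O)OC[C@H]1O[C@H](OC[C@@H](Cn2cc(CN(c3nc(-c4ccc(F)cc4)no3)C3CCCCC3)nn2)OC(C)=O)C=C[C@@H]1OC(C)=O`, a much larger structure, gives 28.8 ug/mL. Both lie below compound 2 by more than the usual scatter.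

Compound 4 `C#CCN(c1nc(-c2ccc(OC)cc2)no1)C1CCCCC1` keeps the structure of compound 2 apart from one change, methoxy in place of hydrogen on an aromatic carbon, para to a large group: methoxy in place of hydrogen on an aromatic carbon.

Among the measured compounds shown here, only one measured step bears on this change, and it is modest: a 2.4-fold higher number from compound 1 to compound 2 (0.38 log units; beyond the scatter), with hydrogen in place of nitro on an aromatic carbon. For the measured compounds named here, it involves a different group, and no methoxy compound has been measured, so it offers only loose guidance. With that single modest step as the guide, and with compound 2 at the top of the measured numbers, a small move to a lower number is expected, possibly none beyond the scatter. The expected change is a 1.4-fold lower number from compound 2 to compound 4 (0.13 log units; within the scatter). For compound 4 the estimate is 80 ug/mL, with an expected range from 40 ug/mL to 160 ug/mL.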

Compound 4, half-maximal cytotoxic concentration: 72.5 ug/mL
Compound 4: the middle estimate sits 1.1-fold (0.04 log units) above what was measured; measured number inside the range.
By their numbers in this assay, from the lowest: compounds 3, 1, 4 and 2 (each within the scatter of the next, the first and the last beyond it).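

Methoxy in place of hydrogen on an aromatic carbon, para to a large group, now has a direct reading in this assay: the step is a 1.5-fold lower number from compound 2 to compound 4 (0.18 log units; within the scatter), so this change does not separate the two compounds in this test. Among the compounds shown here, the only earlier step on an aromatic carbon of the shared core involved a different group and a different comparison, a 2.4-fold higher number from compound 1 to compound 2 (0.38 log units; beyond the scatter), which lies beyond the scatter, so the two pairs now show that a change on this ring may or may not exceed the scatter, depending on the case. Nothing shown here gives a measured reason for either outcome, and no evidence bears on this result.

From the compounds shown here alone, whether an amine, a carboxylic acid or a longer chain such as ethoxy, placed para to the same large group, would stay within the scatter of compound 2 remains open. Also open, going by these compounds, is whether methoxy would give a similar step on another carbon of this ring, or on the much larger structure of compound 3.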